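Swapping the Methoxyphenyl Arm for a Second Bromophenyl

The compounds below may be only part of what the source reports. "The series", "measured", "known", "first", "only" and "open" are said of these compounds alone.

Three measured compounds share one core and differ only in the aryl groups attached to it. In a functional assay on HeLa cells (Homo sapiens) for cytotoxicity, read by CCK-8 assay, with a stated time of 72 h (a lower number here means a stronger inhibitor, a higher number a weaker inhibitor), compound 1 `C=CCn1c(=O)/c(=C\c2cccc(F)c2)[nH]c(=O)/c1=C\c1ccccc1OC` gives 9100 nM, compound 2 `C=CCn1c(=O)/c(=C\c2cccc(Cl)c2Cl)[nH]c(=O)/c1=C\c1ccccc1OC` gives 1600 nM, and compound 3 `C=CCn1c(=O)/c(=C\c2cccc(Br)c2)[nH]c(=O)/c1=C\c1ccccc1OC` gives 5400 nM. Compound 3 therefore stands second highest of the three numbers; a 1.7-fold lower number from compound 1 to compound 3 (0.23 log units; within the scatter) is within the scatter, while a 3.4-fold higher number from compound 2 to compound 3 (0.53 log units; beyond the scatter) lies beyond it. Compound 4 `C=CCn1c(=O)/c(=C\c2cccc(Br)c2)[nH]c(=O)/c1=C\c1cccc(Br)c1` arises from compound 3 by a single change: 3-bromophenyl in place of 2-methoxyphenyl on a double-bonded chain carbon bound to an aromatic carbon. Among the compounds with values here, none of the measured steps concerns the 2-methoxyphenyl group that leaves here; a 5.7-fold lower number from compound 1 to compound 2 (0.75 log units; beyond the scatter), a 1.7-fold lower number from compound 1 to compound 3 (0.23 log units; within the scatter) and a 3.4-fold higher number from compound 2 to compound 3 (0.53 log units; beyond the scatter) all exchange halogens on the other aryl group and range from within the scatter to modest. The data thus give no direct guide for this change, so the expected step is a 1.1-fold lower number from compound 3 to compound 4 (0.03 log units; within the scatter), meaning no shift beyond the scatter, with wide uncertainty. Compound 4 is estimated at 5000 nM, with a range from 1500 nM to 16000 nM in this assay.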

Compound 4, half-maximal inhibitory concentration: "not active" (no number reported)
Compound 4: no number reported; no gap can be computed for the estimate.
By their numbers in this assay, from the lowest: compound 2; then compounds 3 and 1 (each within the scatter of the next).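

Within the data shown here, compound 4 is recorded as "not active" in this assay without a number, so no step from compound 3 to compound 4 can be read. The compounds shown leave open how far this exchange of aryl groups moves the number. No measurement shown here offers an explanation for this result.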